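Aminothiazole in place of oxoimidazolidinone on the fluoronaphthyl series

The source may report more compounds than this note shows. Statements on the series, on what has been measured and on what is new or still open speak of the compounds shown alone.

Measured so far:
compound 1 `CC(C)C(c1ccc(-c2ccc3cccc(F)c3c2)[nH]c1=O)N1CCNC1=O` — 28 nM
compound 2 `CCC(CC)(c1nnc[nH]1)c1ccc(-c2ccc3cccc(F)c3c2)[nH]c1=O` — 36 nM

Both compounds carry the shared core; they differ in the side group on the saturated chain carbon and in the alkyl branch beside it. In a functional assay on CHO cells for antagonist activity at prostaglandin E2 receptor EP3 subtype (Homo sapiens), read by cAMP accumulation (a higher number here means a weaker inhibitor, a lower number a stronger inhibitor), compound 1 gives 28 nM, and compound 2 gives 36 nM in this assay. Compound 1 stands at the low end of the two numbers, but its gap to compound 2 lies within the usual scatter, so the two cannot be separated on these data.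

Compound 3 `CC(C)C(c1cnc(N)s1)c1ccc(-c2ccc3cccc(F)c3c2)[nH]c1=O` has not been measured in this assay. It differs from compound 1 in one place: 2-amino-1,3-thiazol-5-yl in place of 2-oxoimidazolidin-1-yl on a saturated chain carbon bound to an aromatic carbon and a saturated chain carbon. Compound 2 shows that a five-membered aromatic ring with two hetero atoms at this position is tolerated, so no step beyond the scatter is expected; the step of a 1.8-fold higher number from compound 1 to compound 3 (0.25 log units; within the scatter) is the estimate. Compound 3 is expected to give about 50 nM in this assay, in the range 15 nM to 170 nM.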

Compound 3, half-maximal inhibitory concentration: 39 nM
Compound 3: the middle estimate sits 1.3-fold (0.11 log units) above what was measured, and the stated range covers the measured number.
By their numbers in this assay, from the lowest: compounds 1, 2 and 3 (each within the scatter of the next).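

In this assay, 2-amino-1,3-thiazol-5-yl in place of 2-oxoimidazolidin-1-yl gives a 1.4-fold higher number from compound 1 to compound 3 (0.14 log units; within the scatter), so this pair cannot be separated. With everything else held as in compound 1, this position on a saturated chain carbon accepts a five-membered aromatic ring with 2 hetero atoms as well as a five-membered non-aromatic ring with 2 hetero atoms, and a change of ring type and of hetero atoms at equal heavy atom count produces no step beyond the scatter. No measurement offers an explanation for this tolerance.

The compounds shown do not tell whether the amino group on the thiazole matters, since the plain 1,3-thiazol-5-yl group is absent. They also leave open whether a ring is needed here at all, as a simple primary amine or a carboxylic acid at this position would test.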